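Pyridin-3-yl in Place of Phenyl on the Chain Carbon

This account rests on a few compounds, and the source may have more. Where it says the series, first, only, none or still open, it means among the compounds named here.

Compound 3 `COc1ccc([N+](=O)[O-])cc1CSc1nc2cc(NC(=O)NC(C)(C)C)ccc2n1Cc1ccccc1` gives 28 nM in an assay on isolated protein for inhibition of Gonadotropin-releasing hormone receptor (Homo sapiens); a higher number here means a weaker inhibitor, a lower number a stronger inhibitor. Among the three compounds it holds the second highest number: its nearest neighbour is compound 1 `CCCCn1c(SCc2cc([N+](=O)[O-])ccc2OC)nc2cc(NC(=O)NC(C)(C)C)ccc21` with 23 nM, and compound 2 `COCCn1c(SCc2cc([N+](=O)[O-])ccc2OC)nc2cc(NC(=O)NC(C)(C)C)ccc21` with 57 nM stands furthest from it. The step of a 1.2-fold higher number from compound 1 to compound 3 (0.09 log units; within the scatter) lies within the scatter, whereas a 2.0-fold lower number from compound 2 to compound 3 (0.31 log units; beyond the scatter) and a 2.5-fold higher number from compound 1 to compound 2 (0.39 log units; beyond the scatter) are modest. Compound 4 `COc1ccc([N+](=O)[O-])cc1CSc1nc2cc(NC(=O)NC(C)(C)C)ccc2n1Cc1cccnc1` differs from compound 3 by pyridin-3-yl in place of phenyl on a saturated chain carbon bound to an aromatic nitrogen. No measured step exchanges one aromatic ring for another on this chain carbon; the three steps shown move the number only modestly or not at all when the group on that carbon is altered. Compound 4 is therefore expected to show a 1.3-fold higher number from compound 3 to compound 4 (0.10 log units; within the scatter), a step within or close to the scatter. The estimated value of compound 4 in this assay is 35 nM, with a range from 15 nM to 80 nM.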

Compound 4, half-maximal inhibitory concentration: 33 nM
The estimate for compound 4 lay 1.1-fold (0.03 log units) above the measured number; low and high end bracket the measured number.
By their numbers in this assay, from the lowest: compounds 1, 3, 4 and 2 (each within the scatter of the next, the first and the last beyond it).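

Pyridin-3-yl, which brings a ring nitrogen and a hydrogen-bond acceptor that phenyl lacks, is tolerated on this chain carbon in this assay (a 1.2-fold higher number from compound 3 to compound 4 (0.07 log units; within the scatter)). Compound 4 also stands within the scatter of both chain-bearing compounds (a 1.4-fold higher number from compound 1 to compound 4 (0.16 log units; within the scatter); a 1.7-fold lower number from compound 2 to compound 4 (0.24 log units; within the scatter)), although the step between those two lies beyond it. No measured evidence accounts for this tolerance. Open, from the compounds shown here alone, is whether pyridin-2-yl, pyridin-4-yl, or a phenyl carrying an amine or a carboxylic acid would hold the same range at this position.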